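Adding a methoxy to compound 1: working notes

The source may hold more compounds than are shown below. What is called first, only, known or untested is meant among the compounds shown, and "the series" means these compounds.

Compound 1 `O=C(NCc1cn(Cc2ccc(F)cc2)nn1)c1cn(-c2ccccc2)nc1-c1ccccc1` and compound 2 `COc1ccc(Cn2cc(CNC(=O)c3cn(-c4ccccc4)nc3-c3ccccc3)nn2)cc1` are the measured members of the series. For the measured compounds named here, in a functional assay on MIA PaCa-2 cells (Homo sapiens) for antiproliferative activity, read by sulforhodamine B assay, with a stated time of 48 h (a lower number here means a stronger inhibitor of growth, a higher number a weaker inhibitor of growth), compound 1 gives 9600 nM, and compound 2 gives 10200 nM, the two lying within the scatter of each other; the only measured step, a 1.1-fold higher number from compound 1 to compound 2 (0.03 log units; within the scatter), moved nothing. Compound 3 `COc1ccc(-c2nn(-c3ccccc3)cc2C(=O)NCc2cn(Cc3ccc(F)cc3)nn2)cc1` differs from compound 1 by methoxy in place of hydrogen on an aromatic carbon. Going by the values given here, no measured step bears on this change directly, and the one comparison at hand, methoxy in place of fluoro, stayed within the scatter. No step beyond the scatter is therefore expected, no change at the digits printed from compound 1 to compound 3 (within the scatter). Compound 3 is estimated at 9600 nM, in the range 4000 nM to 23000 nM.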

Compound 3, concentration for 50% growth inhibition: 24100 nM
Compound 3: the middle estimate sits 2.5-fold (0.40 log units) below what was measured, outside the stated range (above it).
By their numbers in this assay, from the lowest: compounds 1 and 2 (each within the scatter of the next); then compound 3.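

Phenyl to 4-methoxyphenyl gives, in this assay, a 2.5-fold higher number from compound 1 to compound 3 (0.40 log units; beyond the scatter) and is the only step in the series that lies beyond the scatter, towards weaker growth inhibition. Methoxy is therefore not without effect at this place, whereas methoxy in place of fluoro elsewhere on the molecule gave a 1.1-fold higher number from compound 1 to compound 2 (0.03 log units; within the scatter) and moved nothing. No measurement at hand explains this step. Open, as far as these compounds go, is whether the step is specific to methoxy or would also appear with a hydroxyl, an ethoxy or an amine at this place.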